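This account rests on a few compounds, and the source may have more. Where it says the series, first, only, none or still open, it means among the compounds named here.

Measured so far in a functional assay on Ehrlich cells (Mus musculus) for cytotoxicity, read by trypan blue exclusion, with a stated time of 48 h; a higher number here means a weaker inhibitor, a lower number a stronger inhibitor:
compound 1 `COc1ccc(C(=O)c2cc(C)ccc2OCC(=O)NNC(=O)c2cc3ccccc3oc2=O)cc1`: 41200 nM
compound 2 `Cc1ccc(OCC(=O)NNC(=O)c2cc3ccccc3oc2=O)c(C(=O)c2cccc(Cl)c2)c1`: 67300 nM
compound 3 `Cc1ccc(OCC(=O)NNC(=O)c2cc3ccccc3oc2=O)c(C(=O)c2ccccc2Br)c1`: 9000 nM

Compound 3 gives the lowest number of the three; the gaps to it are a 4.6-fold lower number from compound 1 to compound 3 (0.66 log units; beyond the scatter) and a 7.5-fold lower number from compound 2 to compound 3 (0.87 log units; beyond the scatter), both beyond the scatter, while a 1.6-fold higher number from compound 1 to compound 2 (0.21 log units; within the scatter) lies within it.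

Compound 4 `Cc1ccc(OCC(=O)NNC(=O)c2cc3ccccc3oc2=O)c(C(=O)c2ccccc2)c1` differs from compound 3 by hydrogen in place of bromo on an aromatic carbon. Within the data shown here, both steps into compound 3 put 2-bromophenyl on the carbonyl carbon and lowered the number; no measured step removes a substituent from that ring altogether, so the bearing is indirect. Taking away the bromo is expected to undo part of that gain and move the number back toward compounds 1 and 2. The expected step is a 2.8-fold higher number from compound 3 to compound 4 (0.44 log units; beyond the scatter). Compound 4 is thus estimated at 25000 nM, within 9000 nM to 70000 nM.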

Compound 4, half-maximal inhibitory concentration: 86500 nM
For compound 4 the middle estimate is 3.5-fold (0.54 log units) below the measured one; measured number outside the range, above it.
By their numbers in this assay, from the lowest: compound 3; then compounds 1, 2 and 4 (each within the scatter of the next, the first and the last beyond it).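

Across this series (this assay), the largest step so far comes from removing the bromo (a 9.6-fold higher number from compound 3 to compound 4 (0.98 log units; beyond the scatter)), so the low number of compound 3 depends on that atom and not on the shared core. Phenyl gives no gain over 3-chlorophenyl (a 1.3-fold higher number from compound 2 to compound 4 (0.11 log units; within the scatter)). Against phenyl, 4-methoxyphenyl keeps a modest advantage (a 2.1-fold higher number from compound 1 to compound 4 (0.32 log units; beyond the scatter)), so 2-bromophenyl is not the only ring that improves on it. On these data alone, whether fluoro, methyl or an amine in the place of the bromo would hold the gain remains open. No available evidence accounts for the effect of the bromo.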